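Swapping 2-methylphenyl for 3-methylphenyl: compound 1 to compound 4

The compounds below may be only part of what the source reports. "The series", "measured", "known", "first", "only" and "open" are said of these compounds alone.

Compound 1 `Cc1ccccc1S(=O)(=O)c1ccc(CNC(=O)c2cc3cnccc3[nH]2)cc1` with 15% in an ADME assay on microsomes from liver (Mus musculus) for metabolic stability, read by LC-MS, with a stated time of 30 min, tested at 1 uM; a higher number here means that more of the compound is left, a lower number that less of the compound is left
Compound 2 `O=C(NCc1ccc(S(=O)(=O)c2ccccc2)cc1)c1cc2ccncc2s1` with 21%
Compound 3 `O=C(NCc1ccc(S(=O)(=O)c2ccccc2)cc1)c1cc(-c2cccnc2)[nH]n1` with 42%

Compound 1 and compound 2 lie within the usual scatter of each other, while compound 3 stands higher than compound 1, beyond that scatter. Compound 4 `Cc1cccc(S(=O)(=O)c2ccc(CNC(=O)c3cc4cnccc4[nH]3)cc2)c1` has the same atoms as compound 1, joined differently (3-methylphenyl in place of 2-methylphenyl on a sulfonyl sulfur), with 3-methylphenyl in place of 2-methylphenyl on a sulfonyl sulfur. For the measured compounds named here, no measured pair shows what such a change does. The expectation therefore rests on compound 1 (15%) alone. An expected a number 1 percentage points higher from compound 1 to compound 4 (within the scatter) is estimated to stay within the scatter, with no firm direction. In this assay compound 4 is expected at 16% (estimated range 7% to 30%).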

Compound 4, percent of the compound remaining: 32%
Compound 4: the middle estimate sits 16 percentage points below what was measured, and the stated range ends below it.
By their numbers in this assay, from the lowest: compounds 1 and 2 (each within the scatter of the next); then compounds 4 and 3 (each within the scatter of the next).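

Moving the methyl group within the same set of atoms matters on this sulfonyl sulfur: in this assay, 3-methylphenyl in place of 2-methylphenyl gives a number 17 percentage points higher from compound 1 to compound 4 (beyond the scatter). This is the first change in one place among these compounds, as the earlier ones offered no such pair to read. Nothing at hand explains the step.

As far as these compounds go, what stays open is whether a methoxyphenyl or chlorophenyl group on the sulfonyl sulfur would give a similar number. From the compounds shown here alone, it is also open whether the same change would carry over to a different core.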